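Working notes: chain extension on the shared core

The source may hold more compounds than are shown below. What is called first, only, known or untested is meant among the compounds shown, and "the series" means these compounds.

Three compounds on the shared core have numbers in an assay on cell membranes for binding affinity to adenosine receptor A1 (Cavia porcellus), read by radioligand binding; on this read-out higher numbers stand for weaker inhibition and lower numbers for stronger inhibition. Compound 1 `CCCn1c(=O)c2nc(C(O)(CC)CC)[nH]c2n(CCC)c1=O` gives 170 nM; compound 2 `CCCn1c(=O)c2nc(-c3ccco3)[nH]c2n(CCC)c1=O` gives 560 nM; compound 3 `CCCn1c(=O)c2nc(C(C)(C)C)[nH]c2n(CCC)c1=O` gives 31 nM, the lowest of the three, with compound 1 nearest and compound 2 furthest. The measured steps are a 3.3-fold higher number from compound 1 to compound 2 (0.52 log units; beyond the scatter), a 5.5-fold lower number from compound 1 to compound 3 (0.74 log units; beyond the scatter) and an 18-fold lower number from compound 2 to compound 3 (1.26 log units; beyond the scatter).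

Compound 4 `CCCn1c(=O)c2nc(C(C)(C)CCC)[nH]c2n(CCC)c1=O` is not yet measured. It differs from compound 3 by ethyl in place of hydrogen on a saturated chain carbon, two bonds along the chain from an aromatic carbon. Within the data shown here, no measured step matches this change: each of them exchanges the whole group on the aromatic carbon, whereas here the group stays and is lengthened two bonds along the chain. The nearest guide is a 5.5-fold lower number from compound 1 to compound 3 (0.74 log units; beyond the scatter), which shows a larger group on that carbon giving a weaker number, but that group also carried a hydroxyl, so it does not speak to chain length alone. The expectation is therefore a small step, a 1.5-fold higher number from compound 3 to compound 4 (0.16 log units; within the scatter), most likely within the scatter or somewhat weaker. Compound 4 is estimated at 45 nM in this assay, with a range from 15 nM to 140 nM.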

Compound 4, inhibition constant: 25 nM
Estimate against measurement, compound 4: 1.8-fold (0.26 log units) above, and the stated range covers the measured number.
By their numbers in this assay, from the lowest: compounds 4 and 3 (each within the scatter of the next); then compound 1; then compound 2.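

In this assay, among these compounds, the ethyl on a saturated chain carbon, two bonds along the chain from an aromatic carbon, gives a 1.2-fold lower number from compound 3 to compound 4 (0.09 log units; within the scatter) and so offers the first reading of this group being lengthened, not exchanged: tert-butyl and 1,1-dimethylbutyl cannot be told apart here. The gaps to the other two groups on the aromatic carbon remain clear, with a 6.8-fold lower number from compound 1 to compound 4 (0.83 log units; beyond the scatter) and a 22-fold lower number from compound 2 to compound 4 (1.35 log units; beyond the scatter) both printed as beyond the scatter. Nothing available bears on why the added ethyl leaves the number within the scatter.

Open, on these data alone, is whether a longer chain at this place would stay in the same range as 1,1-dimethylbutyl. Also open, as far as these compounds go, is whether an amine or a carboxylic acid carried on that chain would keep the number there.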